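Swapping One Aryl Group for Another on a Shared Core

A few compounds are considered here, and "the series" means these few. Any claim that something is new, unique, unknown or untested is made for them only; others in the source may bear on it.

Of the compounds shown here, three built on the same core have been tested in a functional assay on CHO cells for agonist activity at adenosine receptor A1 (Homo sapiens), read by fluorescence and ERK phosphorylation, with stated times of 30 min and 1.5 h, tested at 3 uM; on this read-out lower numbers stand for a weaker effect and higher numbers for a stronger effect at the one concentration tested. Compound 3 `Nc1scc(-c2ccccc2F)c1C(=O)c1ccc(Cl)cc1` gives 70% in this assay, the highest of the three numbers. Compound 1 `Nc1scc(-c2ccccc2F)c1C(=O)c1ccccc1` gives 55% in this assay, and compound 2 `Nc1scc(-c2cccc([N+](=O)[O-])c2)c1C(=O)c1ccccc1` gives 47% in this assay; these two values lie within the usual scatter of each other, so nothing about their order can be read from them. Among the compounds with values here, the only step between compounds that differ in a single place is a number 15 percentage points higher from compound 1 to compound 3 (beyond the scatter).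

Compound 4 `Nc1scc(-c2ccc(Br)cc2)c1C(=O)c1ccc(Cl)cc1` has not yet been measured. It differs from compound 3 in one place: 4-bromophenyl in place of 2-fluorophenyl on an aromatic carbon. Within the data shown here, no measured step bears directly on this change, since the one known step, a number 15 percentage points higher from compound 1 to compound 3 (beyond the scatter), concerns a different part of the molecule. Compounds 1 and 2 do differ in the same part of the molecule as compounds 3 and 4, but their values fall within the scatter, giving no direction to lean on. The expected step is therefore a number 8 percentage points lower from compound 3 to compound 4 (within the scatter), meaning no change beyond the scatter is predicted. Compound 4 is thus estimated to give about 62% in this assay, within a range from 38% to 82%.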

Compound 4, a percentage reported as activity, at one concentration (the size of the read-out at that concentration, not a potency): 45%
Compound 4: the middle estimate sits 17 percentage points above what was measured; the measured number falls inside the stated range.
By their numbers in this assay, from the lowest: compounds 4, 2 and 1 (each within the scatter of the next); then compound 3.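

In this assay, within the data shown here, the swap at this carbon of the five-membered ring gives a number 25 percentage points lower from compound 3 to compound 4 (beyond the scatter), the first step at this position that lies beyond the scatter. Among these compounds, compounds 1 and 2 also differ here, but their values are within the scatter of each other, and the only earlier step, a number 15 percentage points higher from compound 1 to compound 3 (beyond the scatter), comes from a chloro group in another part of the molecule, so this result shows that the choice of aryl group at this carbon can itself move the read-out. The 2-fluorophenyl and 4-bromophenyl groups match in heavy-atom count and neither has a hydrogen-bond donor or acceptor, so those counts do not separate them, and no measurement here accounts for the drop.

Because the swap changes both the halogen and where it sits on the phenyl ring, the compounds shown leave open which of the two goes with the lower number. They also leave open how an unsubstituted phenyl or a cyclohexyl group at this carbon would behave alongside the chloro group carried by compound 3.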